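Compound 4 against the methyl-to-nitro steps

This account rests on a few compounds, and the source may have more. Where it says the series, first, only, none or still open, it means among the compounds named here.

Going by the values given here, compound 1 `COc1cccc(OC)c1OCCNCCOc1ccccc1OCc1ccccc1C` gives 7.67 in a functional assay on spleen for antagonist activity at Alpha-1B adrenergic receptor (Rattus norvegicus) (a lower number here means a less potent compound, a higher number a more potent compound, by a factor of ten per unit of this negative logarithm), and is the lowest of the three numbers measured so far. Compound 2 `COc1cccc(OC)c1OCCNCCOc1ccccc1OCc1ccccc1[N+](=O)[O-]` gives 8.56, and compound 3 `COc1cccc(OC)c1OCCNCCOc1ccccc1OCc1ccc([N+](=O)[O-])cc1` gives 9.02. The move to compound 4 `COc1cccc(COc2ccccc2OCCNCCOc2c(OC)cccc2OC)c1` is 3-methoxyphenyl in place of 2-methylphenyl on a saturated chain carbon bound to an oxygen on an aromatic ring. The measured steps at this place are a number 0.89 log units higher from compound 1 to compound 2 (beyond the scatter) and a number 1.35 log units higher from compound 1 to compound 3 (beyond the scatter), with a number 0.46 log units higher from compound 2 to compound 3 (beyond the scatter) between the two nitro compounds. Among the compounds with values here, each of those exchanges methyl for nitro, which is not what enters in compound 4, so they show only that a change at this place can move the number well beyond the scatter in this assay. A smaller upward step is therefore expected: a number 0.23 log units higher from compound 1 to compound 4 (within the scatter). Compound 4 is estimated at 7.9, within 7.3 to 8.5.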

Compound 4, negative logarithm of the antagonist equilibrium constant: 8.31
Estimate against measurement, compound 4: 0.41 log units below; low and high end bracket the measured number.
By their numbers in this assay, from the lowest: compound 1; then compounds 4 and 2 (each within the scatter of the next); then compound 3.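

At this place, a group without a nitro also lifts the number in this assay beyond the scatter (a number 0.64 log units higher from compound 1 to compound 4 (beyond the scatter)), so the rise over compound 1 is not confined to the nitro compounds. 3-Methoxyphenyl falls short of 4-nitrophenyl (a number 0.71 log units lower from compound 3 to compound 4 (beyond the scatter)), while its step against 2-nitrophenyl stays within the scatter (a number 0.25 log units lower from compound 2 to compound 4 (within the scatter)).

Compound 4 changes both the group and where it sits on the ring, so the two contributions cannot be separated. As far as these compounds go, how an amine or a carboxylic acid on that ring would compare also stays open. No measurement available here explains these steps.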